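Swapping the aryl partner of the trimethoxyphenyl core

The source may report more compounds than this note shows. Statements on the series, on what has been measured and on what is new or still open speak of the compounds shown alone.

Three compounds of the series have numbers in a functional assay on HCT-116 cells (Homo sapiens) for inhibition, read by CCK-8 assay, with a stated time of 48 h; a higher number here means a weaker inhibitor, a lower number a stronger inhibitor. Compound 1 `COc1cc(-c2ccnc3cc(-c4cn(CO)c5ccccc45)nn23)cc(OC)c1OC` gives 128 nM. Compound 3 `COc1cc(-c2ccnc3cc(-c4ccc5cc[nH]c5c4)nn23)cc(OC)c1OC` gives 187 nM, the higher of the two numbers shown, but the gap to compound 1 lies within the scatter, so the two read as equivalent. For compound 2 `COc1cc(-c2cc3nccc(-c4c[nH]c5ccccc45)n3n2)cc(OC)c1OC` the result is only a limit of the assay, > 10000 nM; this is the situation described by the limit of > 10000 nM in this assay, at which 1 of the 3 values shown sits, so compound 2 carries no number to compare.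

Compound 4 `COc1ccc(-c2cc3nccc(-c4cc(OC)c(OC)c(OC)c4)n3n2)cc1N` is not yet measured. It differs from compound 3 in one place: 3-amino-4-methoxyphenyl in place of 1H-indol-6-yl on an aromatic carbon. Going by the values given here, no measured pair shows the effect of such a change, so the direction and size of the step are open. The expectation is a modest lowering of the number, a 2.1-fold lower number from compound 3 to compound 4 (0.32 log units; beyond the scatter), possibly not exceeding the scatter. Compound 4 is estimated at 90 nM, within a range from 25 nM to 400 nM.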

Compound 4, half-maximal inhibitory concentration: 251 nM
Compound 4: the middle estimate sits 2.8-fold (0.45 log units) below what was measured, and the stated range covers the measured number.
By their numbers in this assay, from the lowest: compounds 1, 3 and 4 (each within the scatter of the next). At a limit, above all of these: compound 2.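

In this assay the change to 3-amino-4-methoxyphenyl in place of 1H-indol-6-yl gives a 1.3-fold higher number from compound 3 to compound 4 (0.13 log units; within the scatter) and so compound 3 and compound 4 read as equivalent. This aromatic carbon therefore accepts one six-membered aromatic ring of carbon only as well as the indolyl group, even though the five-membered aromatic ring leaves and 2 hydrogen-bond acceptors enter. Nothing among the data shown accounts for this equivalence.

Whether the amino or the methoxy group of 3-amino-4-methoxyphenyl contributes on its own stays open, as no compound shown carries one without the other. On these data alone, how an unsubstituted phenyl or a 3-hydroxy-4-methoxyphenyl group would read at this position is also open.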